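Shortening the amide side chain from compound 2 to compound 3

A few compounds are considered here, and "the series" means these few. Any claim that something is new, unique, unknown or untested is made for them only; others in the source may bear on it.

Among the measured compounds shown here, compound 2 `CCCNC(=O)[C@@H]1CN[C@H](C(=O)N2CCC[C@H]2C#N)C1` is the only entry with a number in hand: in an assay on the whole organism (plasma, strain Sprague-Dawley) for inhibition of Dipeptidyl peptidase 4 (Rattus norvegicus), with a stated time of 10 h, at a dose of 1 mg/kg by the oral route (on this read-out lower numbers stand for less inhibition and higher numbers for more inhibition at the one dose given (going by the name of the read-out)), compound 2 gives 21%. Compound 1 `CCN(CC)C(=O)[C@@H]1CN[C@H](C(=O)N2CCC[C@H]2C#N)C1` has no number in this assay, its entry for compound 1 reading "not determined" (no result reported). Compound 3 `CCNC(=O)[C@@H]1CN[C@H](C(=O)N2CCC[C@H]2C#N)C1` is still to be measured and differs from compound 2 by hydrogen in place of methyl on a saturated chain carbon, two bonds along the chain from an amide-type nitrogen. For the measured compounds named here, no step between two measured compounds is available, so nothing of this kind has yet been observed. A step that stays within the scatter, in no set direction, is expected, a number 1 percentage points lower from compound 2 to compound 3 (within the scatter). For compound 3 in this assay the estimate is 20%, with a range from 5% to 40%.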

Compound 3, a percentage reported as inhibition, in the whole organism at one dose (the size of the read-out at that dose, not a potency): 19%
For compound 3 the middle estimate is 1 percentage points above the measured one, within the range that was stated.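

Hydrogen in place of methyl on a saturated chain carbon, two bonds along the chain from an amide-type nitrogen, gives a number 2 percentage points lower from compound 2 to compound 3 (within the scatter) in this assay. Among the compounds shown here, this is the first step that can be read at this position, and on this read-out the propyl and ethyl side chains cannot be told apart. No measured evidence bears on this result. Still open, going by these compounds, is whether a longer chain such as butyl, or an amine or carboxylic acid at the end of the chain, would give a step beyond the scatter.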